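Shrinking the Saturated Ring: Compound 3 to Compound 4

This account rests on a few compounds, and the source may have more. Where it says the series, first, only, none or still open, it means among the compounds named here.

Compound 1, `COc1ccc2oc(CSC(=S)N3CCOCC3)cc(=O)c2c1`, in a functional assay on MCF7 cells (Homo sapiens) for antiproliferative activity, read by MTT assay, with a stated time of 72 h (on this read-out higher numbers stand for weaker inhibition and lower numbers for stronger inhibition), gives > 25000 nM, a limit of the assay and not a number.
Compound 2, `O=c1cc(CSC(=S)N2CCCCC2)oc2ccccc12`, in this assay gives > 25000 nM, again a limit of the assay.
Compound 3, `O=c1c(Cl)c(CSC(=S)N2CCCCC2)oc2ccccc12`, in this assay gives 1000 nM.

Within the data shown here, compound 3 holds the only number among the three results; the other two sit at the limit of > 25000 nM in this assay, at which 2 of the 3 values shown sit. Among the measured compounds shown here, the one measured step, an at least 25-fold lower number from compound 2 to compound 3 (1.39 log units; beyond the scatter), turns on a chloro in place of a hydrogen on an aromatic carbon and says nothing about the amine attached to the thiocarbonyl carbon.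

Compound 4, `O=c1c(Cl)c(CSC(=S)N2CCCC2)oc2ccccc12`, differs from compound 3 in exactly that amine: pyrrolidin-1-yl in place of piperidin-1-yl on a thiocarbonyl carbon. For the measured compounds named here, no measured step touches this part of the molecule, so the expectation rests on compound 3 alone. Compound 3 gives 1000 nM, and the step to compound 4 is expected to be a 1.2-fold higher number from compound 3 to compound 4 (0.08 log units; within the scatter), which is no step beyond the scatter in either direction. For compound 4 the estimated value in this assay is 1200 nM, with a range from 400 nM to 4000 nM.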

Compound 4, half-maximal inhibitory concentration: 2300 nM
For compound 4 the middle estimate is 1.9-fold (0.28 log units) below the measured one; measured number inside the range.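

Among these compounds, compound 4 supplies the first measured step at the amine on the thiocarbonyl carbon: in this assay, pyrrolidin-1-yl in place of piperidin-1-yl gives a 2.3-fold higher number from compound 3 to compound 4 (0.36 log units; beyond the scatter), modest in size but beyond the scatter. The amine is therefore not a silent part of the molecule, although this change is much smaller than the step on the aromatic carbon, an at least 25-fold lower number from compound 2 to compound 3 (1.39 log units; beyond the scatter), and both chlorinated compounds keep a measurable number with either saturated ring. The results show only that the smaller ring goes with the higher number, and nothing shown speaks to the reason for the difference.

Whether the same amine change would matter without the chloro cannot be read from the compounds shown, and the same holds for any step involving compound 1, which differs from the chlorinated compounds in more than one place. From the compounds shown here alone, how an open-chain diethylamino group or a larger azepan-1-yl ring would behave on the thiocarbonyl carbon of the chlorinated core remains open.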